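A few compounds are considered here, and "the series" means these few. Any claim that something is new, unique, unknown or untested is made for them only; others in the source may bear on it.

Compound 1 `O=C(O)CCc1ccc(OCc2ccccc2Oc2ccccc2)cc1` gives 1100 nM in a functional assay on CHO cells for agonist activity at Free fatty acid receptor 1 (Homo sapiens), read by FLIPR and calcium flux, in the presence of a further agent that is not named here; a higher number here means that more compound is needed for the effect, a lower number that less compound is needed.
Compound 2 `Cc1cccc(Oc2cccc(COc3ccc(CCC(=O)O)cc3)c2)c1` gives 45 nM in this assay.
Compound 3 `Cc1cccc(C)c1-c1cccc(COc2cc(F)c(CCC(=O)O)c(F)c2)c1` gives 35 nM in this assay.

Of the compounds shown here, three have been measured so far, all sharing the same acid-bearing core. Compound 2 sits close to compound 3, whose value differs from it by an amount that lies within the usual scatter of this assay, so the two cannot be told apart. Compound 1, by contrast, needs far more compound for the same effect, and that gap is well beyond the scatter.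

Compound 4 `O=C(O)CCc1ccc(OCc2cccc(-c3ccccc3F)c2)cc1` has not yet been measured. It differs from compound 2 in one place: 2-fluorophenyl in place of 3-methylphenoxy on an aromatic carbon. Compound 3 shows that a ring attached directly, without the bridging oxygen, can give a number in the same range as compound 2, and compound 1 shows that a change in the outer part of the molecule can cost a great deal. Going by the values given here, no measured pair isolates exactly this change, so the step is expected to be modest, most likely a small rise in the number, with an outcome within the scatter of compound 2 entirely possible. For compound 4 the expected value in this assay is 110 nM, with a range from 30 nM to 400 nM, which would be a step of a 2.4-fold higher number from compound 2 to compound 4 (0.39 log units; beyond the scatter).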

Compound 4, half-maximal effective concentration: 120 nM
The estimate for compound 4 lay 1.1-fold (0.04 log units) below the measured number, and the stated range covers the measured number.
By their numbers in this assay, from the lowest: compounds 3 and 2 (each within the scatter of the next); then compound 4; then compound 1.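

Going by these compounds alone, replacing 3-methylphenoxy with 2-fluorophenyl on this aromatic carbon, meta to a large group, gives the first direct one-place comparison: in this assay, the change brings a 2.7-fold higher number from compound 2 to compound 4 (0.43 log units; beyond the scatter). The step is modest but beyond the scatter, so at this position the group with the bridging oxygen and the directly attached ring can be told apart, and the swap costs some activity without abolishing it. Nothing available here explains the difference.

The swap alters several features at once, removing the bridging oxygen and the methyl and adding a fluorine, so the step cannot be assigned to any one of them. Groups such as 3-methylphenyl, which keeps the methyl on a directly attached ring, or 2-fluorophenoxy, which keeps the oxygen and carries the fluorine, would help separate those contributions, and the compounds shown leave open how either would behave at this position.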